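The compounds below may be only part of what the source reports. "The series", "measured", "known", "first", "only" and "open" are said of these compounds alone.

Working notes on the series, all read in a functional assay on NCI-H1975 cells (Homo sapiens) for inhibition, with a stated time of 72 h; on this read-out higher numbers stand for weaker inhibition of growth and lower numbers for stronger inhibition of growth. Compound 1 `COC(=O)c1ccc(CN(C)C(=O)c2cc(C(C)C)c(O)cc2O)cc1` gives 3500 nM, compound 2 `CN(Cc1ccc(C(=O)NO)cc1)C(=O)c1cc(Cl)c(O)cc1O` gives 68800 nM, and compound 3 `CCCN(Cc1ccc(C(=O)NO)cc1)C(=O)c1cc(Cl)c(O)cc1O` gives 73600 nM. Compound 2 thus stands at the high end of these numbers, within the scatter of compound 3 and clearly higher than compound 1.

Compound 4 `CC(C)c1cc(C(=O)N(C)Cc2ccc(C(=O)NO)cc2)c(O)cc1O` is not yet measured. It has isopropyl in place of chloro on an aromatic carbon of compound 2, ortho to a hydroxy group and para to a hydroxy group: isopropyl in place of chloro on an aromatic carbon.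

Among the compounds with values here, the only measured step, a 1.1-fold higher number from compound 2 to compound 3 (0.03 log units; within the scatter), lies within the scatter, but it is a change on a saturated chain carbon bound to an amide-type nitrogen, so it says little about this aromatic position. Within the data shown here, the closer evidence is compound 1, the only measured compound with the isopropyl, at 3500 nM. Among the measured compounds shown here, it also differs from compound 4 elsewhere, so this value is only a loose guide, and no measured pair isolates chloro against isopropyl.

A lower number in this assay, beyond the scatter, is therefore expected, with an estimated size of a 14-fold lower number from compound 2 to compound 4 (1.14 log units; beyond the scatter). For compound 4 the estimate is 5000 nM, with an expected range of 1000 nM to 30000 nM.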

Compound 4, concentration for 50% growth inhibition: 1700 nM
Compound 4: middle estimate off by 2.9-fold (0.47 log units), on the high side; measured number inside the range.
By their numbers in this assay, from the lowest: compound 4; then compound 1; then compounds 2 and 3 (each within the scatter of the next).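

In this assay this aromatic position, ortho to a hydroxy group and para to a hydroxy group, proves highly responsive: isopropyl in place of chloro gives a 40-fold lower number from compound 2 to compound 4 (1.61 log units; beyond the scatter) and is a large step, whereas the earlier change on the saturated chain carbon bound to the amide-type nitrogen gave only a 1.1-fold higher number from compound 2 to compound 3 (0.03 log units; within the scatter) and lay within the scatter. With the isopropyl held constant, hydroxyamino in place of methoxy on the carbonyl carbon gives a 2.1-fold lower number from compound 1 to compound 4 (0.31 log units; beyond the scatter) and is a modest step, so among these compounds the larger shift belongs to the aromatic position. Nothing on hand accounts for either step.

Going by these compounds, whether the lower number is specific to isopropyl remains open, since hydrogen, ethyl, tert-butyl or methoxy at this aromatic position would be needed to define the trend, and it is also unknown whether isopropyl has the same effect alongside the longer nitrogen chain of compound 3. Equally open, on these data alone, is how a carboxylic acid or a primary amide would read in place of the hydroxyamino on the carbonyl carbon, and how chloro would read with methoxy there.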